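Changing One End of Compound 1 and Expecting Compound 4

The source may hold more compounds than are shown below. What is called first, only, known or untested is meant among the compounds shown, and "the series" means these compounds.

Compound 1 `CC(C)(C)OC(=O)C(=O)Nc1cccccc1=O` was tested in a functional assay on the whole organism (strain Sprague-Dawley CD) for inhibition, with Rattus norvegicus as the target, read by paw edema, at a dose of 30 mg/kg by the intraperitoneal route (a lower number here means a weaker effect, a higher number a stronger effect of the compound at the dose given), where compound 1 gives 79%. Two relatives share its core. Compound 2 `O=C(O)C(=O)Nc1cccccc1=O` was measured more than once, and in this assay compound 2 gives 77%; 75% (2 entries). Compound 3 `O=C(Nc1cccccc1=O)C(=O)Oc1ccccc1` carries phenyl in place of tert-butyl on an oxygen next to a carbonyl group, and in this assay compound 3 gives 73%. Among the measured compounds shown here, the only single change with two measured ends is a number 6 percentage points lower from compound 1 to compound 3 (within the scatter). On these numbers compound 1 and compound 3 cannot be told apart, and the repeat readings of compound 2 the several entries of compound 2 in this assay, 77%; 75% (2 entries) sit in the same band.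

Compound 4 `NNC(=O)C(=O)Nc1cccccc1=O` is not yet measured. It differs from compound 1 by aminoamino in place of tert-butoxy on a carbonyl carbon. The nearest measured comparison is a number 6 percentage points lower from compound 1 to compound 3 (within the scatter), which stayed within the scatter, and compound 2 also sits in that band. For the measured compounds named here, no measured step bears directly on putting aminoamino in the place of tert-butoxy, so the expectation rests on how little this end has mattered so far. The step in this assay is therefore expected to be small, a number 5 percentage points lower from compound 1 to compound 4 (within the scatter), in no firm direction. Compound 4 is estimated at 74%, with a range from 62% to 84%.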

Compound 4, a percentage reported as inhibition, in the whole organism at one dose (the size of the read-out at that dose, not a potency): 78%
For compound 4 the middle estimate is 4 percentage points below the measured one; low and high end bracket the measured number.
By their numbers in this assay, from the lowest: compounds 3, 4 and 1 (each within the scatter of the next).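

Among the compounds shown here, compound 4 is the first compound here with nitrogen rather than oxygen attached to this carbonyl carbon, so the change tests more than another oxygen-linked end. In this assay, replacing tert-butoxy with aminoamino gives a number 1 percentage points lower from compound 1 to compound 4 (within the scatter), even though the entering group has fewer heavy atoms and brings two hydrogen-bond donors where the leaving group has none. At this dose, then, the read-out does not separate these two ends, and the same band also holds the repeat readings of compound 2: the several entries of compound 2 in this assay, 77%; 75% (2 entries)

Because every reading comes from a single dose and shows the size of the effect rather than potency, these compounds leave open whether a lower dose would pull them apart. They also leave open whether a simple amine or a longer alkyl chain on this carbonyl carbon would fit the same band, and whether changing the shared core, which stays the same throughout, would matter more than changing this end.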